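The source may hold more compounds than are shown below. What is called first, only, known or untested is meant among the compounds shown, and "the series" means these compounds.

Measured so far in a functional assay on MDA-MB-435 cells (Homo sapiens) for cytotoxicity, read by MTT assay, with a stated time of 72 h; on this read-out higher numbers stand for weaker inhibition and lower numbers for stronger inhibition:
- compound 1 `CS(=O)(=O)Oc1c(C(=O)NCc2ccc(F)cc2)nc(Br)c2cccnc12`: > 20000 nM, a limit of the assay and not a number
- compound 2 `NCCCNc1c(C(=O)NCc2ccc(F)cc2)nc(Br)c2cccnc12`: 5000 nM

Going by the values given here, compound 2, at 5000 nM, holds the only exact number so far, so there is no spread of values against which to rank it. The next compound is compound 3 `NCCCNc1c(C(=O)NCc2ccc(F)cc2)ncc2cccnc12`, which differs from compound 2 at one place: hydrogen in place of bromo on an aromatic carbon. This puts hydrogen in place of bromo on an aromatic carbon, para to a (3-aminopropyl)amino group.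

Among the compounds with values here, the single measured step is an at least 4.0-fold lower number from compound 1 to compound 2 (0.60 log units; beyond the scatter). That step bears only loosely on this change, since it exchanges (methylsulfonyl)oxy for (3-aminopropyl)amino at another place and the bromo is present in both compounds. Within the data shown here, no measured step shows what removing the bromo does, so neither its size nor its direction can be carried over.

The estimated step is a 1.2-fold higher number from compound 2 to compound 3 (0.08 log units; within the scatter), which is expected to stay within the scatter, although a shift either way remains possible. For compound 3 the expected value in this assay is 6000 nM, with an estimated range from 1800 nM to 20000 nM.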

Compound 3, half-maximal inhibitory concentration: 16000 nM
Compound 3: middle estimate off by 2.7-fold (0.43 log units), on the low side, within the range that was stated.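

Bromo on this aromatic carbon, next to the ring nitrogen and para to a (3-aminopropyl)amino group, now has a measured effect of its own in this assay: hydrogen in place of bromo gives a 3.2-fold higher number from compound 2 to compound 3 (0.51 log units; beyond the scatter). The earlier step could not show this, as bromo was present on both of its sides. With the (3-aminopropyl)amino group held fixed, the bromo-bearing member of this pair gives the lower number, so that group alone does not account for the value of compound 2, and any weaker neighbour of compound 3 may leave little room on the read-out before the limit seen for compound 1, which is a limit and not a number: the limit of > 20000 nM in this assay, at which 1 of the 3 values shown sits.

Open, on these data alone, is whether the step is specific to bromo or would also appear with chloro, methyl or trifluoromethyl on the same carbon, which would show if a substituent of another kind serves there as well. Also open, as far as these compounds go, is whether the same exchange carries over when a longer chain or a carboxylic acid replaces the (3-aminopropyl)amino group.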